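Methoxy in Place of Hydrogen: Expected Tolerance of Compound 4

The compounds below may be only part of what the source reports. "The series", "measured", "known", "first", "only" and "open" are said of these compounds alone.

Measured so far in an ADME assay on Vero cells (Chlorocebus sabaeus) for cytotoxicity, read by fluorescence and resazurin assay, with a stated time of 72 h; a higher number here means that more compound is tolerated, a lower number that less compound is tolerated:
compound 1, `CC1=CSC2=NC(/C=C/c3ccccc3Cl)=C(C(=O)/C=C/c3ccccc3Cl)C(c3ccccc3)N12`, gives 206 ug/mL;
compound 2, `CC1=CSC2=NC(/C=C/c3ccc(F)cc3)=C(C(=O)/C=C/c3ccc(F)cc3)C(c3ccccc3)N12`, gives 306 ug/mL;
compound 3, `COc1ccc(C2C(C(=O)/C=C/c3ccccc3)=C(/C=C/c3ccccc3)N=C3SC=C(C)N32)cc1`, gives 211 ug/mL.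

Compound 2 shows the highest of these three numbers, yet its gaps to compound 3 and to compound 1 both lie within the scatter, so the three compounds cannot be told apart on tolerance. Compound 4, `COc1ccc(C2C(C(=O)/C=C/c3ccc(F)cc3)=C(/C=C/c3ccc(F)cc3)N=C3SC=C(C)N32)cc1`, is not yet measured. It differs from compound 2 by one change: methoxy in place of hydrogen on an aromatic carbon. Among the measured compounds shown here, no measured pair shows this change on its own, so there is no step to lean on. The expected step from compound 2 to compound 4 is a 1.1-fold lower number from compound 2 to compound 4 (0.04 log units; within the scatter), that is, none beyond the scatter. Compound 4 is therefore estimated at 280 ug/mL, within 150 ug/mL to 520 ug/mL.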

Compound 4, half-maximal cytotoxic concentration: 261 ug/mL
Compound 4: the middle estimate sits 1.1-fold (0.03 log units) above what was measured, within the range that was stated.
By their numbers in this assay, from the lowest: compounds 1, 3, 4 and 2 (each within the scatter of the next).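

Among the compounds shown here, compound 2 and compound 4 form the first pair here that differs in one place only, and in this assay the step is a 1.2-fold lower number from compound 2 to compound 4 (0.07 log units; within the scatter), which lies within the scatter. Phenyl to 4-methoxyphenyl at this position therefore leaves no detectable mark on tolerance, at least with the side arms these two compounds share. No other measurement here bears on the reason for this result.

As far as these compounds go, whether an amine, a carboxylic acid or a longer chain such as ethoxy at this place would shift the number beyond the scatter stays open. So does whether methoxy would behave the same way with the side arms of compound 1.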